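Cytotoxicity at the Assay Limit for Three Amides

The source may hold more compounds than are shown below. What is called first, only, known or untested is meant among the compounds shown, and "the series" means these compounds.

Compound 1 `Cc1cc(C)cc(NC(=O)COc2cc(C)nc3ccc(Cl)cc23)c1` in a toxicity assay on HepG2 cells (Homo sapiens) for inhibition, read by CellTiter-Glo, with a stated time of 48 h (a higher number here means a weaker inhibitor, a lower number a stronger inhibitor), gives > 100000 nM, which is a limit of the assay and not a number.
Compound 2 `COc1ccc2nc(C)cc(OC(C)(C)C(=O)Nc3cc(C)cc(C)c3)c2c1` in this assay gives > 100000 nM, again a limit.
Compound 3 `COc1ccc2nc(C)cc(OCC(=O)Nc3cc(C)ccc3OC)c2c1` in this assay gives > 100000 nM, also a limit.

Compound 3 therefore stands where every measured value in this set stands: at the limit, with no number to rank it against compound 1 or compound 2 (the limit of > 100000 nM in this assay, at which 3 of the 3 values shown sit). For the measured compounds named here, no pair of measured compounds differs in a single place, so no measured step is available to draw on.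

Compound 4 `COc1ccc2nc(C)cc(OCC(=O)Nc3cccnc3)c2c1` has not yet been measured. It differs from compound 3 in one place: pyridin-3-yl in place of 2-methoxy-5-methylphenyl on an amide-type nitrogen. With all measured values sitting at the limit, no step beyond the usual scatter in this assay is expected in either direction. Compound 4 is expected to give 100000 nM, with a range from 50000 nM to 200000 nM. The step from compound 3 to compound 4 is thus estimated as a number no higher from compound 3 to compound 4 (the limit leaves the size open), and the result for compound 4 is expected most likely to be reported again as a limit rather than a number.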

Compound 4, half-maximal inhibitory concentration: > 100000 nM
Compound 4 ended at the assay's limit; the forecaster's own chance of this, stated with the estimate: 85%; the middle value sits exactly at the limit.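

In this assay, for the compounds shown here, compound 3 and compound 4 both sit at a limit, and no step between them can be read: the limit of > 100000 nM in this assay, at which 4 of the 4 values shown sit. The compounds shown leave open how far each lies past that limit and what change would bring a measurable value.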